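Methoxy on the anilino ring: a small expected shift

The compounds below may be only part of what the source reports. "The series", "measured", "known", "first", "only" and "open" are said of these compounds alone.

Compound 1 `Cc1nc(SCC(=O)Nc2nc(-c3ccc(Cl)cc3)cs2)n(Nc2ccccc2)c1C` gives 3000 nM in a functional assay on OVCAR-3 cells (Homo sapiens) for antiproliferative activity, read by sulforhodamine B assay, with a stated time of 48 h; on this read-out lower numbers stand for stronger inhibition of growth and higher numbers for weaker inhibition of growth.
Compound 2 `Cc1ccc(Nn2c(SCC(=O)Nc3nc(-c4ccccc4)cs3)nc(C)c2C)cc1` gives 8240 nM.

Compound 1 stands at the lowest of the two numbers; compound 2 sits beyond the scatter above it, though the two differ in more than one place, so the values only show the gap. Compound 3 `COc1ccc(Nn2c(SCC(=O)Nc3nc(-c4ccc(Cl)cc4)cs3)nc(C)c2C)cc1` differs from compound 1 by methoxy in place of hydrogen on an aromatic carbon, a methoxy in place of hydrogen on an aromatic carbon. For the measured compounds named here, with no single-change pair to lean on, the step of a 1.2-fold higher number from compound 1 to compound 3 (0.07 log units; within the scatter) is expected to stay near the scatter. Compound 3 is estimated at 3500 nM, in the range 1200 nM to 10000 nM.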

Compound 3, concentration for 50% growth inhibition: 3130 nM
Compound 3: middle estimate off by 1.1-fold (0.05 log units), on the high side; the measured number falls inside the stated range.
By their numbers in this assay, from the lowest: compounds 1 and 3 (each within the scatter of the next); then compound 2.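

In this assay the change from phenyl to 4-methoxyphenyl gives a 1.0-fold higher number from compound 1 to compound 3 (0.02 log units; within the scatter) and stays within the scatter. For the compounds shown here, this is the first single-change pair, and it shows that this aromatic carbon, para to a large group, takes a methoxy with no readable change in growth inhibition. Nothing measured here offers an explanation for this result.

The compounds shown leave open whether an amine or a carboxylic acid on the same carbon would also leave the number in place. They also leave open whether a longer chain such as butoxy would do so.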